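The source may hold more compounds than are shown below. What is called first, only, known or untested is meant among the compounds shown, and "the series" means these compounds.

Measured compounds in a toxicity assay on GES1 cells (Homo sapiens) for inhibition, read by MTT assay, with a stated time of 72 h; a lower number here means a stronger inhibitor, a higher number a weaker inhibitor:
- compound 1 `Cc1cc(N2CC[C@@H](C)[C@@H](N(C)c3ncnc4[nH]ccc34)C2)n2nc(SCc3ccccc3)nc2n1`: 67200 nM
- compound 2 `Cc1cc(N2CC[C@@H](C)[C@@H](N(C)c3ncnc4[nH]ccc34)C2)n2nc(SCc3ccc(Cl)cc3)nc2n1`: > 100000 nM (a limit of the assay, not a number)
- compound 3 `Cc1cc(N2CC[C@@H](C)[C@@H](N(C)c3ncnc4[nH]ccc34)C2)n2ncnc2n1`: 57900 nM

Compound 2 stands at the limit of > 100000 nM in this assay, at which 1 of the 3 values shown sits; for compound 2 only a limit is known, no number. The step of an at least 1.4-fold higher number from compound 1 to compound 2 (0.17 log units; that floor lies within the scatter) therefore has only a floor, and that floor lies within the scatter. The step of a 1.2-fold lower number from compound 1 to compound 3 (0.06 log units; within the scatter) is within the scatter, and the step of an at least 1.7-fold lower number from compound 2 to compound 3 (0.23 log units; that floor lies within the scatter) again gives only a floor that lies within the scatter. Across the three compounds the group on the sulfur-bearing aromatic carbon, whether absent, benzylsulfanyl or (4-chlorobenzyl)sulfanyl, moves this assay by no more than the scatter allows one to see.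

Compound 4 `C=CCSc1nc2nc(C)cc(N3CC[C@@H](C)[C@@H](N(C)c4ncnc5[nH]ccc45)C3)n2n1` is not yet measured. Relative to compound 2 the change is vinyl in place of 4-chlorophenyl on a saturated chain carbon bound to a sulfur. Going by the values given here, the steps that bear on it are an at least 1.4-fold higher number from compound 1 to compound 2 (0.17 log units; that floor lies within the scatter) and an at least 1.7-fold lower number from compound 2 to compound 3 (0.23 log units; that floor lies within the scatter), both small at their floors, and a 1.2-fold lower number from compound 1 to compound 3 (0.06 log units; within the scatter), which is within the scatter. The expected step of an at least 1.4-fold lower number from compound 2 to compound 4 (0.15 log units; that floor lies within the scatter) is therefore a modest lowering, or none beyond the scatter, with a real chance that the assay again reports only a limit. The estimate for compound 4 is 70000 nM, with a range from 35000 nM to 140000 nM.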

Compound 4, half-maximal inhibitory concentration: > 100000 nM
Compound 4 gave a limit, no number (the forecaster's own chance of this, stated with the estimate: 40%); at least 1.4-fold (0.15 log units) between middle value and limit.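

In this assay, replacing the aromatic end of the sulfanyl group with vinyl leaves compound 4 at a limit of the assay, not a number (> 100000 nM), so a reading this weak does not depend on the 4-chlorophenyl group. The two readable steps, the gain of allylsulfanyl (an at least 1.7-fold higher number from compound 3 to compound 4 (0.23 log units; that floor lies within the scatter)) and vinyl in place of phenyl on a saturated chain carbon bound to a sulfur (an at least 1.4-fold higher number from compound 1 to compound 4 (0.17 log units; that floor lies within the scatter)), give only floors within the scatter, so neither shows a real change at this position. The step between compound 2 and compound 4 cannot be read because both compounds sit at the limit: the limit of > 100000 nM in this assay, at which 2 of the 4 values shown sit.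

On these data alone, whether compound 2 and compound 4 differ beyond the limit remains open, as does the true size of their gaps to compound 1 and compound 3. As far as these compounds go, it is also open whether an amine, a carboxylic acid or a longer chain in place of the vinyl would move the number in this assay beyond the scatter.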